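A Methoxy Addition and Expected Cytotoxicity

This account rests on a few compounds, and the source may have more. Where it says the series, first, only, none or still open, it means among the compounds named here.

For the measured compounds named here, compound 3 `Nc1nc(Cl)c(-c2nc3ccccc3s2)c(N[C@@H]2C[C@H](CO)[C@@H](O)[C@H]2O)n1` gives the only number among the three measured in an ADME assay on cells (Homo sapiens) for cytotoxicity, read by polymerase chain reaction, with a stated time of 3 days (a higher number here means that more compound is tolerated, a lower number that less compound is tolerated), where compound 3 sits at 14000 nM. Compound 1 `Nc1nc(Cl)c(-c2ncco2)c(N[C@@H]2C[C@H](CO)[C@@H](O)[C@H]2O)n1` sits at a limit of the assay, > 25000 nM. Compound 2 `Nc1nc(Cl)c(-c2cc3ccccc3s2)c(N[C@@H]2C[C@H](CO)[C@@H](O)[C@H]2O)n1` likewise sits at a limit, > 25000 nM. The steps of an at least 1.7-fold lower number from compound 1 to compound 3 (0.25 log units; that floor lies within the scatter) and an at least 1.7-fold lower number from compound 2 to compound 3 (0.25 log units; that floor lies within the scatter) rest on (the limit of > 25000 nM in this assay, at which 2 of the 3 values shown sit), and the step that the two limits leave unreadable from compound 1 to compound 2 cannot be read. Compound 4 `COc1ccc2nc(-c3c(Cl)nc(N)nc3N[C@@H]3C[C@H](CO)[C@@H](O)[C@H]3O)sc2c1` differs from compound 3 by methoxy in place of hydrogen on an aromatic carbon. Going by the values given here, no measured step exchanges hydrogen for methoxy; the steps seen move whole aryl groups and reach only a floor inside the scatter. Compound 4 is therefore expected to show no step beyond the scatter, no change at the digits printed from compound 3 to compound 4 (within the scatter). Compound 4 is estimated at 14000 nM, between 7000 nM and 30000 nM, with a fair chance that this assay returns only a limit.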

Compound 4, half-maximal cytotoxic concentration: > 25000 nM
Compound 4: a limit, no number; the forecaster's own chance of this, stated with the estimate: 40%; at least 1.7-fold (0.25 log units) between middle value and limit.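

In this assay, methoxy in place of hydrogen on an aromatic carbon gives an at least 1.7-fold higher number from compound 3 to compound 4 (0.25 log units; that floor lies within the scatter). This is the first step shown at this position, and it adds no sign that methoxy here lowers the number, but it establishes no change beyond the scatter. Compound 4 gives only a limit, so the size of the step cannot be read: the limit of > 25000 nM in this assay, at which 3 of the 4 values shown sit.

From the compounds shown here alone, whether an amine or a hydroxyl group at the same position would give a readable number stays open. So does whether methoxy elsewhere on this ring would read the same.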